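The source may hold more compounds than are shown below. What is called first, only, known or untested is meant among the compounds shown, and "the series" means these compounds.

Of the compounds shown here, three that share one core have been measured in a functional assay on NCI-H226 cells (Homo sapiens) for cytotoxicity, read by sulforhodamine B assay, with a stated time of 48 h, tested at 10 uM; a lower number here means a stronger effect, a higher number a weaker effect of the compound at the concentration tested. Compound 3 `COc1ccc(C(=O)/C=C/c2cc(-c3cc(OC)c(OC)c(OC)c3)n[nH]2)cc1OC` gives -81%, the low end of the three numbers. Compound 1 `COc1cc(-c2cc(/C=C/C(=O)c3ccc(N)cc3)[nH]n2)cc(OC)c1OC` gives -73%, and a number 8 percentage points lower from compound 1 to compound 3 (within the scatter) lies within the scatter, so the two cannot be told apart. Compound 2 `COc1cc(-c2cc(/C=C/C(=O)c3ccc(Cl)c(Cl)c3)[nH]n2)cc(OC)c1OC` gives 67%, and a number 148 percentage points lower from compound 2 to compound 3 (beyond the scatter) is a large change; in the same way a number 140 percentage points higher from compound 1 to compound 2 (beyond the scatter) is large.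

Compound 4 `COc1ccc(C(=O)/C=C/c2cc(-c3cc(OC)c(OC)c(OC)c3)n[nH]2)cc1` differs from compound 3 in one place: hydrogen in place of methoxy on an aromatic carbon. Cut one bond further out, the change reads 3,4-dimethoxyphenyl to 4-methoxyphenyl. Going by the values given here, no measured step removes a single methoxy; every measured step swaps the whole ring on the carbonyl carbon. The step from compound 2 to compound 3 shows that this ring can move the read-out strongly, while the step from compound 1 to compound 3 shows that two quite different rings can also give nearly the same number. Losing one methoxy is a smaller change than either of those swaps, so the expected step is a number 26 percentage points higher from compound 3 to compound 4 (beyond the scatter), with room for a weaker outcome. Compound 4 is estimated at -55%, within a range from -95% to 30%.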

Compound 4, a percentage reported as activity, at one concentration (the size of the read-out at that concentration, not a potency): -59%
Estimate against measurement, compound 4: 4 percentage points above; the measured number falls inside the stated range.
By their numbers in this assay, from the lowest: compounds 3 and 1 (each within the scatter of the next); then compound 4; then compound 2.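

In this assay, going by these compounds alone, a number 22 percentage points higher from compound 3 to compound 4 (beyond the scatter) is the first change of a single group on this ring, and it shows that the methoxy ortho to a methoxy group has a modest but real effect on the read-out, although compound 4, at -59%, stays negative like compound 3. With that methoxy gone, the ring remains far from the 3,4-dichlorophenyl of compound 2, as a number 126 percentage points lower from compound 2 to compound 4 (beyond the scatter) is a large step, while the 4-methoxyphenyl and 4-aminophenyl rings can now be told apart, as a number 14 percentage points higher from compound 1 to compound 4 (beyond the scatter) is a modest step beyond the scatter. Nothing here gives a measured explanation for any of these steps, so the numbers show their size and leave their cause unknown.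

The compounds shown leave open whether it matters which group stands at the place the methoxy left, as a hydroxy group, a fluorine atom or an ethoxy group there would test. They also leave open whether the remaining methoxy of compound 4 can be removed as well, giving a plain phenyl ring, without losing the negative read-out.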